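This account rests on a few compounds, and the source may have more. Where it says the series, first, only, none or still open, it means among the compounds named here.

Compound 1 `CCOC(=O)c1ccc(-c2nn(Cc3ccc(F)cc3)c3ccccc23)cc1`: > 10000 nM
Compound 2 `CCOC(=O)c1ccc(-c2nn(-c3ccco3)c3ccccc23)cc1`: > 10000 nM

In a functional assay on cells (Platelet, Homo sapiens) for inhibition (a lower number here means a stronger inhibitor, a higher number a weaker inhibitor), compound 2 gives > 10000 nM, which is a limit of the assay and not a number. Compound 1 gives > 10000 nM, also a limit. The whole record so far is therefore (the limit of > 10000 nM in this assay, at which 2 of the 2 values shown sit), and compound 2 has no exact value from which to count.

Compound 3 `CCOC(=O)c1ccc(-c2nn(C(C)C)c3ccccc23)cc1` keeps the shared core and changes one group: isopropyl in place of furan-2-yl on an aromatic nitrogen. In words, isopropyl takes the place of furan-2-yl on an aromatic nitrogen.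

For the measured compounds named here, one measured step touches this same nitrogen: a step that the two limits leave unreadable from compound 1 to compound 2. It offers no size to carry over, since both of its ends are limits. Going by the values given here, two different groups at this nitrogen have thus given no measurable inhibition, and the smaller isopropyl has no measured precedent. The most reasonable expectation is that compound 3 also reaches the limit, with no readable change in either direction.

The expected change is a step that the limit leaves unreadable from compound 2 to compound 3. For compound 3 the estimate is 15000 nM, with an expected range from 5000 nM to 40000 nM.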

Compound 3, half-maximal inhibitory concentration: > 10000 nM
Compound 3 gave a limit, no number (the forecaster's own chance of this, stated with the estimate: 85%); the middle value does not contradict the limit.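

In this assay compound 3 gives > 10000 nM, which is a limit of the assay and not a number. The steps linking compound 1, compound 2 and compound 3 therefore cannot be read. It remains open whether any group on this aromatic nitrogen would give a readable value, and the record so far is: the limit of > 10000 nM in this assay, at which 3 of the 3 values shown sit.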